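The source may report more compounds than this note shows. Statements on the series, on what has been measured and on what is new or still open speak of the compounds shown alone.

Measured so far in an ADME assay on a cell-free system (plasma, Homo sapiens) for protein binding:
compound 1 `COCc1nc2nc(C)cc(Nc3ccc(C(F)(F)F)cc3)n2n1`: 75.6%
compound 2 `Cc1cc(Nc2cccc(Cl)c2)n2nc(C(C)(F)F)nc2n1`: 88.2%
compound 3 `Cc1cc(Nc2ccc(S(F)(F)(F)(F)F)cc2)n2nc(C(C)(F)F)nc2n1`: 97.4%

Among these three, compound 1 shows the highest unbound fraction. Compound 2 is nearest to it, and the gap between the two lies beyond the scatter of repeated measurements; compound 3 is furthest from compound 1, again well beyond the scatter. Within the data shown here, no pair of measured compounds differs in a single place, so no measured step is available to calibrate a new change.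

Compound 4 `CSc1nc2nc(C)cc(Nc3ccc(C(F)(F)F)cc3)n2n1` differs from compound 1 in one place: methylsulfanyl in place of methoxymethyl on an aromatic carbon. The two groups are of similar size and carry the same count of hydrogen-bond acceptors, so a large shift is not expected. In this assay compound 4 is expected to give 84%, with a range from 70% to 93%. The step a 1.5-fold lower unbound fraction from compound 1 to compound 4 (0.18 log units; within the scatter) is estimated to be modest, toward a higher bound fraction, near the edge of the usual scatter.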

Compound 4, plasma protein binding: 91.8%
The estimate for compound 4 lay 2.0-fold (0.29 log units) (unbound fraction) above the measured number, within the range that was stated.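

With the rest of compound 1 unchanged, methylsulfanyl in place of methoxymethyl on an aromatic carbon gives a 3.0-fold lower unbound fraction from compound 1 to compound 4 (0.47 log units; beyond the scatter) in this assay. Among these compounds, this is the first single-place comparison, and it shows that this position, between two ring nitrogen atoms of the five-membered aromatic ring, can shift the read-out beyond the scatter even when the entering and leaving groups have matching counts of hydrogen-bond donors and acceptors. No measurement shown here accounts for the size or direction of this shift.

The compounds shown leave open whether the step follows from the sulfur atom or from the shorter chain, which methoxy and ethyl at this position would help to separate. They also leave open how an amine or a carboxylic acid at this position would compare with methoxymethyl.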